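Guanidine in place of a primary amine on a shared core

The source may report more compounds than this note shows. Statements on the series, on what has been measured and on what is new or still open speak of the compounds shown alone.

Of the compounds shown here, three sharing one core have been measured in an assay on cells for inhibition of Voltage-dependent T-type calcium channel subunit alpha-1H (Homo sapiens), read by FLIPR and calcium flux, with stated times of 600 s and 300 s; a higher number here means a weaker inhibitor, a lower number a stronger inhibitor. Compound 1 `CN(Cc1ccc(OCCCNC(=N)N)cc1)c1nc2ccc(Oc3ccccc3)cc2s1` gives 498000 nM. Within the data shown here, compound 2 `CN(Cc1ccc(OCCCNC(=N)N)cc1)c1nc2ccc(Oc3ccc(C(F)(F)F)cc3)cc2s1` gives 212000 nM; the single change between them, a 2.3-fold lower number from compound 1 to compound 2 (0.37 log units; beyond the scatter), is the only step between two measured compounds that differ in one place. Compound 3 `CN(Cc1ccc(OCCCN)cc1)c1nc2ccc(Oc3ccc(O)cc3)cc2s1` gives 165000 nM, the lowest of the three numbers, but its gap to compound 2 lies within the scatter, so the two cannot be ordered; only its gap to compound 1 is beyond the scatter.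

Compound 4 `CN(Cc1ccc(OCCCNC(=N)N)cc1)c1nc2ccc(Oc3ccc(O)cc3)cc2s1` is not yet measured. It differs from compound 3 in one place: a group of 3 heavy atoms (1 carbon, 2 nitrogen; no ring) in place of a hydrogen atom, on an amine nitrogen. Among the measured compounds shown here, no measured pair isolates this change, so no step bears on it directly. For the measured compounds named here, the only guidance is that compound 1 and compound 2 already carry the entering group, and their numbers are in the same broad region as that of compound 3. On that ground the number of compound 4 is expected to stay close to that of compound 3, with a 1.2-fold higher number from compound 3 to compound 4 (0.08 log units; within the scatter) as the estimated step. Compound 4 is therefore expected to give about 200000 nM, in a range from 80000 nM to 500000 nM.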

Compound 4, half-maximal inhibitory concentration: 332000 nM
The estimate for compound 4 lay 1.7-fold (0.22 log units) below the measured number, within the range that was stated.
By their numbers in this assay, from the lowest: compounds 3, 2, 4 and 1 (each within the scatter of the next, the first and the last beyond it).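

Among these compounds, compound 3 and compound 4 form the first pair to isolate the change on the amine nitrogen whose other neighbour is a saturated chain carbon, and in this assay the group of 3 heavy atoms in place of a hydrogen atom gives a step that stays within the scatter (a 2.0-fold higher number from compound 3 to compound 4 (0.30 log units; within the scatter)), so this pair cannot show that guanidine and primary amine differ at this position. Hydroxy on the aromatic carbon also cannot be told apart from the other two groups with guanidine in place, both as a replacement for trifluoromethyl (a 1.6-fold higher number from compound 2 to compound 4 (0.19 log units; within the scatter)) and as a replacement for hydrogen (a 1.5-fold lower number from compound 1 to compound 4 (0.18 log units; within the scatter)), so compound 4 cannot be ordered against compound 1 or compound 2. Nothing among the data given accounts for these numbers.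

The compounds shown leave open whether a carboxylic acid or a longer chain in place of the primary amine would move the number beyond the scatter. They also leave open whether trifluoromethyl or hydrogen in place of hydroxy on the aromatic carbon would give a similar result when paired with the primary amine rather than guanidine.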